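Trading a Substituted Anilino Group for Plain Phenyl

This account rests on a few compounds, and the source may have more. Where it says the series, first, only, none or still open, it means among the compounds named here.

compound 1 `COc1cc(-c2nn(-c3cccc(NC(=O)Nc4cccc(C(F)(F)F)c4)c3)cc2-c2ccncc2)ccc1Cl` — 50000 nM
compound 2 `COc1cc(-c2nn(-c3cccc(NC(=O)Nc4ccc(Cl)c(C(F)(F)F)c4)c3)cc2-c2ccncc2)ccc1Cl` — > 32500 nM

Of the compounds shown here, two have been measured in a functional assay on MDA-MB-468 cells (Homo sapiens) for inhibition, read by sulforhodamine B assay, with a stated time of 48 h; a lower number here means that less compound is tolerated, a higher number that more compound is tolerated. Compound 1 `COc1cc(-c2nn(-c3cccc(NC(=O)Nc4cccc(C(F)(F)F)c4)c3)cc2-c2ccncc2)ccc1Cl` gives 50000 nM in this assay, a very high concentration, meaning the cells tolerate a great deal of it. For compound 2 `COc1cc(-c2nn(-c3cccc(NC(=O)Nc4ccc(Cl)c(C(F)(F)F)c4)c3)cc2-c2ccncc2)ccc1Cl` the result is only a limit, > 32500 nM, so its true value is not known. The step that the limit leaves unreadable from compound 1 to compound 2 therefore cannot be read, as the limit of > 32500 nM in this assay, at which 1 of the 2 values shown sits, shows. What can be said is that both compounds are tolerated up to the top of the tested range.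

Compound 3 `COc1cc(-c2nn(-c3cccc(NC(=O)c4ccccc4)c3)cc2-c2ccncc2)ccc1Cl` differs from compound 2 in one place: phenyl in place of (4-chloro-3-(trifluoromethyl)phenyl)amino on a carbonyl carbon. The carbonyl carbon thus carries a phenyl directly instead of a nitrogen bearing a substituted ring. Among the measured compounds shown here, no measured step bears on this change, and the only measured step is unreadable. Compound 1 and compound 2 both sit at the upper edge of what this assay can report, and the estimate for compound 3 rests on that alone. Compound 3 is expected to stay at that edge, with a step that the limit leaves unreadable from compound 2 to compound 3. The expected value for compound 3 in this assay is 40000 nM, between 12000 nM and 100000 nM, with a real chance that only a limit is reported.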

Compound 3, concentration lethal to 50% of the cells: > 100000 nM
Compound 3 was reported as a limit; the forecaster's own chance of this, stated with the estimate: 55%; at least 2.5-fold (0.39 log units) between middle value and limit.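

On the carbonyl carbon, replacing (3-(trifluoromethyl)phenyl)amino with phenyl gives an at least 2.0-fold higher number from compound 1 to compound 3 (0.30 log units; that floor lies within the scatter) in this assay, so this exchange shows no sign of lowering the number, although the printed floor of the step does not establish a real rise. As far as these compounds go, compound 3 is reported only as a limit, > 100000 nM, so the phenyl compound also yields no exact value, and the true size of the step stays unknown. Compound 2 is likewise a limit, so neither step that involves it can be read: the limit of > 32500 nM in this assay, at which 1 of the 3 values shown sits.

The compounds shown therefore do not reveal which feature of the group on the carbonyl carbon, if any, can bring the number down, since none of the three gives a low value in this assay. From the compounds shown here alone, it remains open whether a different group at this place, such as a morpholine ring joined through its nitrogen or a short chain ending in a carboxylic acid, would give a lower, exactly measurable value.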